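The source may hold more compounds than are shown below. What is called first, only, known or untested is meant among the compounds shown, and "the series" means these compounds.

The study concerns a set of amide compounds that share the same core and differ in the substituted aryl groups attached to it. Compound 1 `CCN(Cc1ccccc1)C(=O)c1nc(-c2ccc(F)cc2)c2ccccc2n1` carries a 4-fluorophenyl group, and in an assay on cell membranes from kidney for displacement of a labelled ligand from Translocator protein (Rattus norvegicus) (a higher number here means a weaker inhibitor, a lower number a stronger inhibitor), compound 1 gives 1.68 nM. Compound 2 `CCN(Cc1ccccc1)C(=O)c1nc(-c2ccc(Cl)cc2)c2ccccc2n1` has a 4-chlorophenyl group in its place; in this assay compound 2 gives 0.762 nM. The change between them, (chloro in place of fluoro on an aromatic carbon), made a step of a 2.2-fold lower number from compound 1 to compound 2 (0.34 log units; beyond the scatter).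

Compound 3 `CCN(Cc1ccc(C)cc1)C(=O)c1nc(-c2ccccc2F)c2ccccc2n1` differs from compound 1 in more than one place, and the difference between the two cores is not broken down here. In this assay compound 3 gives 0.6 nM, the lowest of the three numbers, although its gap to compound 2 lies within the scatter and only its gap to compound 1 lies beyond it.

Compound 4 `CCN(Cc1ccc(C)cc1)C(=O)c1nc(-c2ccccc2Cl)c2ccccc2n1` is not yet measured. It differs from compound 3 by chloro in place of fluoro on an aromatic carbon. Among the compounds with values here, this is the same kind of change as the one from compound 1 to compound 2, but not the same: there the place was "para to a large group", here it is "ortho to a large group". Resting on the step of a 2.2-fold lower number from compound 1 to compound 2 (0.34 log units; beyond the scatter) and on the value of compound 3 of 0.6 nM, compound 4 is expected to show a step of a 1.7-fold lower number from compound 3 to compound 4 (0.23 log units; within the scatter) in this assay. The estimate for compound 4 is therefore 0.35 nM, with a range from 0.15 nM to 0.9 nM.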

Compound 4, inhibition constant: 0.489 nM
The estimate for compound 4 lay 1.4-fold (0.15 log units) below the measured number, and the stated range covers the measured number.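

In this assay, within the data shown here, chloro in place of fluoro on the core of compound 3 gave a 1.2-fold lower number from compound 3 to compound 4 (0.09 log units; within the scatter), so at this place, ortho to a large group, the 2-fluorophenyl to 2-chlorophenyl exchange produced no step that can be told from the scatter. Set beside the earlier case, the step on the core of compound 1 was beyond the scatter and this one was within it, yet the two cannot be told apart: the same change on two cores in this assay, a 2.2-fold lower number (0.34 log units; beyond the scatter) from compound 1 to compound 2 and a 1.2-fold lower number (0.09 log units; within the scatter) from compound 3 to compound 4, 1.8-fold (0.25 log units) apart, within the scatter of two such steps. Among these compounds, this is consistent with the change carrying over from one core to the other, but it rests on only two pairs and does not show that the change keeps the same size across the series, nor does it separate the effect of the place on the ring from that of the rest of the core, since the two pairs differ in both.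

The compounds shown leave open how bromo, methoxy or trifluoromethyl would compare with fluoro and chloro at either place on the ring. They also leave open what would follow if the ethyl on the amide nitrogen gave way to a longer chain, or the benzyl group to a different one.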